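One Aromatic Group Exchanged in a Receptor Agonist Series

The source may hold more compounds than are shown below. What is called first, only, known or untested is meant among the compounds shown, and "the series" means these compounds.

Three measured compounds share one core and differ only in the aromatic group attached to it. Compound 1 `O=C(O)CCc1ccc(OCc2nc(-c3ccccc3Cl)no2)cc1` carries a 2-chlorophenyl group, and in a functional assay on CHO cells for agonist activity at Free fatty acid receptor 1 (Homo sapiens), read by FLIPR and calcium flux, in the presence of a further agent that is not named here (a higher number here means that more compound is needed for the effect, a lower number that less compound is needed), compound 1 gives 1200 nM. Compound 2 `O=C(O)CCc1ccc(OCc2nc(-c3ccccc3)no2)cc1` carries a plain phenyl group, and in this assay compound 2 gives 1130 nM; the step of a 1.1-fold lower number from compound 1 to compound 2 (0.03 log units; within the scatter) shows that taking away the chloro changes nothing that can be trusted. Compound 3 `CCc1ccc(-c2noc(COc3ccc(CCC(=O)O)cc3)n2)cc1` carries a 4-ethylphenyl group, and in this assay compound 3 gives 210 nM, the lowest number of the three; the steps of a 5.7-fold lower number from compound 1 to compound 3 (0.76 log units; beyond the scatter) and a 5.4-fold lower number from compound 2 to compound 3 (0.73 log units; beyond the scatter) are both beyond the scatter, so compound 3 stands clearly apart from the other two.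

Compound 4 `Cc1cc(-c2noc(COc3ccc(CCC(=O)O)cc3)n2)ccc1F` has not yet been measured. It differs from compound 3 in one place: 4-fluoro-3-methylphenyl in place of 4-ethylphenyl on an aromatic carbon. The entering group carries a fluorine and a methyl instead of the ethyl. Going by the values given here, the steps that bear on this are a 5.4-fold lower number from compound 2 to compound 3 (0.73 log units; beyond the scatter), which shows how much the ethyl was worth, and a 1.1-fold lower number from compound 1 to compound 2 (0.03 log units; within the scatter), which shows a halogen making no difference beyond the scatter. Compound 4 is therefore expected to give back part of the gain seen for compound 3, by a step of a 2.1-fold higher number from compound 3 to compound 4 (0.33 log units; beyond the scatter). In this assay compound 4 is estimated at 450 nM, with a range from 150 nM to 1300 nM.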

Compound 4, half-maximal effective concentration: 2120 nM
Estimate against measurement, compound 4: 4.7-fold (0.67 log units) below, and the stated range ends below it.
By their numbers in this assay, from the lowest: compound 3; then compounds 2, 1 and 4 (each within the scatter of the next).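

The exchange gives a 10-fold higher number from compound 3 to compound 4 (1.00 log units; beyond the scatter) in this assay, so at this position the benefit is tied to the 4-ethylphenyl group and does not come with just any added groups on the phenyl ring, even though both groups count the same number of heavy atoms and neither has a hydrogen-bond donor or acceptor. The plain phenyl and 2-chlorophenyl groups offer the fairest comparison, and the steps of a 1.9-fold higher number from compound 2 to compound 4 (0.27 log units; within the scatter) and a 1.8-fold higher number from compound 1 to compound 4 (0.25 log units; within the scatter) are both within the scatter, which means that compound 4 cannot be told apart from compound 2 or compound 1. Nothing presented here gives a measured reason for this difference.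

The fluorine and the methyl entered together, so the compounds shown leave open what each does alone, as a 4-fluorophenyl or a 3-methylphenyl group would reveal. They also leave open whether the gain seen with the ethyl group would persist, grow or vanish with a longer chain such as propyl, or with a methoxy group in the same place on the phenyl ring.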